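Fluoro to Ethoxy: A Small Expected Step

The source may report more compounds than this note shows. Statements on the series, on what has been measured and on what is new or still open speak of the compounds shown alone.

In a functional assay on A549 cells (Homo sapiens) for antiproliferative activity, read by MTT assay, with a stated time of 48 h (a lower number here means a stronger inhibitor, a higher number a weaker inhibitor), compound 1 `COc1ccc(/C=C/c2cc(OC)cc(OC)c2/C=C/C(=O)c2cccc(Cl)c2)cc1` gives 5.6 ug/mL, compound 2 `COc1ccc(/C=C/c2cc(OC)cc(OC)c2/C=C/C(=O)c2ccc(N)cc2)cc1` gives 3.8 ug/mL and compound 3 `COc1ccc(/C=C/c2cc(OC)cc(OC)c2/C=C/C(=O)c2ccc(F)cc2)cc1` gives 6.6 ug/mL. Compound 3 therefore stands within the scatter of both others. Compound 4 `CCOc1ccc(C(=O)/C=C/c2c(/C=C/c3ccc(OC)cc3)cc(OC)cc2OC)cc1` keeps the shared core but carries ethoxy in place of fluoro on an aromatic carbon, para to a large group: ethoxy in place of fluoro on an aromatic carbon. Going by the values given here, no measured step makes this exact swap. The closest evidence is a 1.7-fold higher number from compound 2 to compound 3 (0.24 log units; within the scatter), with fluoro in place of amino, alongside a 1.2-fold higher number from compound 1 to compound 3 (0.07 log units; within the scatter) and a 1.5-fold lower number from compound 1 to compound 2 (0.17 log units; within the scatter). All three stay within the scatter, so no step beyond it is expected here. The estimate is a 1.3-fold lower number from compound 3 to compound 4 (0.12 log units; within the scatter). For compound 4 the expected value is 5 ug/mL, with an estimated range of 2.5 ug/mL to 10 ug/mL.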

Compound 4, half-maximal inhibitory concentration: 7.5 ug/mL
For compound 4 the middle estimate is 1.5-fold (0.18 log units) below the measured one; low and high end bracket the measured number.
By their numbers in this assay, from the lowest: compounds 2, 1, 3 and 4 (each within the scatter of the next).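

In this assay, putting ethoxy in place of fluoro on this ring gives two compounds that cannot be told apart, with a 1.1-fold higher number from compound 3 to compound 4 (0.06 log units; within the scatter). The other two comparisons, a 2.0-fold higher number from compound 2 to compound 4 (0.30 log units; within the scatter) and a 1.3-fold higher number from compound 1 to compound 4 (0.13 log units; within the scatter), also stay within the scatter, so this ethoxy group, the first chain at this ring position among these compounds, does not set compound 4 apart from any of them. Nothing measured here offers an explanation for this result. From the compounds shown here alone, whether a longer chain such as butoxy, or a carboxylic acid, at this position would separate from these compounds remains open.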